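The source may hold more compounds than are shown below. What is called first, only, known or untested is meant among the compounds shown, and "the series" means these compounds.

Measured so far in an assay on CHO cells for displacement of a labelled ligand from muscarinic acetylcholine receptor M5 (Homo sapiens), read by scintillation counting, with a stated time of 2 h; on this read-out higher numbers stand for weaker inhibition and lower numbers for stronger inhibition:
- compound 1 `COc1ccc(CCOC(=O)N(c2ccccc2)C2CN3CCC2CC3)cc1`: 230 nM
- compound 2 `COc1ccc(COC(=O)N(c2ccccc2)C2CN3CCC2CC3)cc1F`: 40 nM

Compound 2 holds the lowest of the two numbers; its nearest neighbour is compound 1, and the step of a 5.8-fold lower number from compound 1 to compound 2 (0.76 log units; beyond the scatter) lies beyond the scatter. Compound 3 `O=C(OCc1ccccc1)N(c1ccccc1)C1CN2CCC1CC2` is not yet measured. It differs from compound 2 in one place: phenyl in place of 3-fluoro-4-methoxyphenyl on a saturated chain carbon bound to an oxygen next to a carbonyl group. For the measured compounds named here, the only measured step, from compound 1 to compound 2, touches the same place but swaps both chain length and substituents at once, so it bears on the present step only loosely; no step removes fluorine and methoxy alone. Stripping the aromatic ring bare is taken as a likely loss, of modest size and with wide uncertainty. The expected step for compound 3 is a 3.0-fold higher number from compound 2 to compound 3 (0.48 log units; beyond the scatter), towards a higher number. Compound 3 is therefore estimated at 120 nM in this assay, within 40 nM to 400 nM.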

Compound 3, inhibition constant: 150 nM
Compound 3: middle estimate off by 1.3-fold (0.10 log units), on the low side, within the range that was stated.
By their numbers in this assay, from the lowest: compound 2; then compounds 3 and 1 (each within the scatter of the next).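

In this assay, the change from 3-fluoro-4-methoxyphenyl to phenyl, on a saturated chain carbon bound to an oxygen next to a carbonyl group, gives a 3.8-fold higher number from compound 2 to compound 3 (0.57 log units; beyond the scatter). This isolates the fluorine and methoxy pair as a single change, which the earlier step, mixing chain length and substituents, could not do. Phenyl in place of 4-methoxybenzyl gives a 1.5-fold lower number from compound 1 to compound 3 (0.19 log units; within the scatter), so these two groups are not told apart at this place, and no evidence is available to explain either step.

Whether fluorine alone or methoxy alone accounts for the step from phenyl remains open, since the two only appear together here. Also open, on these data alone, is how a chloro group or an amine on the same aromatic ring would read.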